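Two Weak Antiproliferatives and an Untested Analogue

A few compounds are considered here, and "the series" means these few. Any claim that something is new, unique, unknown or untested is made for them only; others in the source may bear on it.

Measured compounds:
compound 1 `C[C@@H]1CC(=O)C=C2CC[C@@H]([C@@]3(C)CO3)C[C@]21C`: 27.6 ug/mL
compound 2 `C=C(C)[C@@H]1C[C@@H](O)C2=CC(=O)C[C@@H](C)[C@]2(C)C1`: 25.7 ug/mL

In a functional assay on HL-60 cells (Homo sapiens) for antiproliferative activity, read by MTT assay (on this read-out lower numbers stand for stronger inhibition and higher numbers for weaker inhibition), compound 1 gives 27.6 ug/mL, and compound 2 gives 25.7 ug/mL. Compound 1 has the highest of the two numbers, but compound 2 sits within the scatter of it, so the two cannot be told apart on these figures. Compound 3 `C=C(CO)[C@@H]1CCC2=CC(=O)C[C@@H](C)[C@]2(C)C1` has not yet been measured in this assay. It differs from compound 1 in one place: 1-(hydroxymethyl)ethenyl in place of 2-methyloxiran-2-yl on a saturated ring carbon. The 2-methyloxiran-2-yl group leaves and the 1-(hydroxymethyl)ethenyl group enters on a saturated ring carbon of a six-membered non-aromatic ring of carbon only, part of a fused or bridged system of two rings; the two structures have the same atoms, joined differently. For the measured compounds named here, no pair of measured compounds differing in one place is at hand, so there is no measured step to lean on, and the two measured values lie close together. The estimate for compound 3 means a step of a 1.1-fold higher number from compound 1 to compound 3 (0.04 log units; within the scatter), which is expected to stay within the scatter. Compound 3 is estimated at 30 ug/mL, with a range from 12 ug/mL to 75 ug/mL in this assay.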

Compound 3, concentration for 50% inhibition: 4.4 ug/mL
The estimate for compound 3 lay 6.8-fold (0.83 log units) above the measured number; the whole stated range lies above it.
By their numbers in this assay, from the lowest: compound 3; then compounds 2 and 1 (each within the scatter of the next).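

In this assay, the exchange of 2-methyloxiran-2-yl for 1-(hydroxymethyl)ethenyl on this saturated ring carbon gives a 6.3-fold lower number from compound 1 to compound 3 (0.80 log units; beyond the scatter), the first step read at this position, and it shows that the number responds to what the position carries. The step comes with no change in the count of heavy atoms or in the atoms themselves: the three-membered ring gives way to an open group with a double bond and a hydrogen-bond donor, so the way those atoms are joined is enough to move the number beyond the scatter. No measurement at hand explains why the number falls with this exchange.

The hydroxymethyl part and the ethenyl part enter together, so the compounds shown cannot say whether the step belongs to one of them or needs both. On these data alone, it also remains open how the number would respond to a plain isopropenyl group, to an aminomethyl group in place of the hydroxymethyl, or to a carboxylic acid on the same ring carbon.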